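The compounds below may be only part of what the source reports. "The series", "measured", "known", "first", "only" and "open" are said of these compounds alone.

In a functional assay, with a stated time of 30 min (a higher number here means a weaker inhibitor, a lower number a stronger inhibitor), compound 2 `COc1ccc(C2CC(=NOC(=O)c3cc(O)cc(O)c3)CC(c3ccc(OC)cc3)N2C)cc1` gives 19000 nM. Its only comparator, compound 1 `COc1ccc(C2CC(=NOC(=O)c3cccc(O)c3)CC(c3ccc(OC)cc3)N2C)cc1`, gives 34000 nM, and the step of a 1.8-fold lower number from compound 1 to compound 2 (0.25 log units; within the scatter) lies within the usual scatter, so neither compound can be called the stronger of the two. Compound 3 `COc1ccc(C2CC(=NOC(=O)c3ccc(OC)cc3OC)CC(c3ccc(OC)cc3)N2C)cc1` has not yet been measured. It differs from compound 2 in one place: 2,4-dimethoxyphenyl in place of 3,5-dihydroxyphenyl on a carbonyl carbon. Among the compounds with values here, no measured step removes both hydroxy groups or introduces methoxy groups, so the only guide is the single step already seen, which added one hydroxy group. Because that step a 1.8-fold lower number from compound 1 to compound 2 (0.25 log units; within the scatter) stayed within the scatter, the expectation for compound 3 is a step of a 1.6-fold higher number from compound 2 to compound 3 (0.20 log units; within the scatter) that also stays within the scatter, with no confident direction. Compound 3 is therefore expected to give about 30000 nM in this assay, with a likely range from 10000 nM to 100000 nM.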

Compound 3, half-maximal inhibitory concentration: 80000 nM
The estimate for compound 3 lay 2.7-fold (0.43 log units) below the measured number; measured number inside the range.
By their numbers in this assay, from the lowest: compounds 2 and 1 (each within the scatter of the next); then compound 3.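

In this assay, the group on this carbonyl carbon can shift the number beyond the scatter: a 4.2-fold higher number from compound 2 to compound 3 (0.62 log units; beyond the scatter), and a 2.4-fold higher number from compound 1 to compound 3 (0.37 log units; beyond the scatter), whereas the earlier step between the two hydroxy-bearing groups stayed within it. Among these three compounds, 2,4-dimethoxyphenyl therefore gives the weakest inhibitor, although both steps are modest. Nothing available explains this loss of strength.

The change from 3,5-dihydroxyphenyl to 2,4-dimethoxyphenyl alters both the kind of group and where the groups stand on the ring, so these compounds cannot show which of the two matters. Also open, as far as these compounds go, is how an unsubstituted phenyl, or an aromatic ring carrying an amine or a carboxylic acid, would behave on this carbonyl carbon.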